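Inverting One Stereocentre of Compound 2

The source may report more compounds than this note shows. Statements on the series, on what has been measured and on what is new or still open speak of the compounds shown alone.

- Compound 1 `CCOC(=O)[C@@]1(C(=O)Nc2ccccc2)C[C@@H]1c1cc(OC)c(OC)c(OC)c1` gives > 100000 nM
- Compound 2 `CCOC(=O)[C@@]1(C(=O)Nc2ccccc2Cl)C[C@@H]1c1cc(OC)c(OC)c(OC)c1` gives > 100000 nM
- Compound 3 `COc1cc([C@H]2C[C@@]2(CO)C(=O)Nc2ccccc2Cl)cc(OC)c1OC` gives > 100000 nM

These three results come from a functional assay on HeLa cells (Homo sapiens) for cytotoxicity, read by MTT assay, with a stated time of 48 h (a higher number here means a weaker inhibitor, a lower number a stronger inhibitor), and each is a limit, not a number. Compound 2 therefore has no exact position, and its entry of > 100000 nM is only a limit. The whole series rests on (the limit of > 100000 nM in this assay, at which 3 of the 3 values shown sit).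

Compound 4 `CCOC(=O)[C@@]1(C(=O)Nc2ccccc2Cl)C[C@H]1c1cc(OC)c(OC)c(OC)c1` is the next compound to consider, and the change from compound 2 is this: the two compounds have the same atoms and bonds and differ only in configuration as drawn: 1 of 2 stereo elements differ; a stereocentre at a saturated ring carbon is drawn R in compound 2 and S in compound 4. The measured steps are a step that the two limits leave unreadable from compound 1 to compound 2 and a step that the two limits leave unreadable from compound 2 to compound 3. Neither has a readable size, and neither alters configuration, so neither supplies a size for this change. No shift beyond the scatter, in either direction, can be forecast in this assay. The expected change is a number no higher from compound 2 to compound 4 (the limit leaves the size open). The limit is also the likeliest report for this compound. For compound 4 the estimated value is 100000 nM, with an expected range from 30000 nM to 200000 nM.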

Compound 4, half-maximal inhibitory concentration: 14400 nM
Beside the measured number, compound 4's estimate is 6.9-fold (0.84 log units) above it; the measured number lies below the stated range.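

Inverting the stereocentre at the saturated ring carbon, drawn R in compound 2 and S in compound 4, is the only change shown that brings a value off the limit in this assay, giving an at least 6.9-fold lower number from compound 2 to compound 4 (0.84 log units; beyond the scatter), while the other steps cannot be read. On these data alone, the full size of this step stays open, since the entry for compound 2 is a limit: the limit of > 100000 nM in this assay, at which 3 of the 4 values shown sit. The step can be assigned to configuration at this one carbon alone, with no group entering or leaving: the fact that compounds 2 and 4 differ only in the configuration as drawn.

The compounds shown leave open whether the same inversion would bring compound 1 or compound 3 off the limit. They also leave open how compound 4 would respond to a carboxylic acid in place of its ethoxycarbonyl group.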